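Swapping a Methylcyclohexyl Amide for an Oxolane

The source may report more compounds than this note shows. Statements on the series, on what has been measured and on what is new or still open speak of the compounds shown alone.

Measured so far in an assay on HEK293 cells for positive allosteric modulation of metabotropic glutamate receptor 5 (Homo sapiens), read by FLIPR; on this read-out higher numbers stand for an effect only at larger amounts of compound and lower numbers for an effect already at smaller amounts:
compound 1, `CC1CCC(C(=O)N2CC(c3nc(-c4cccc(Cl)c4)no3)C2)CC1`, gives 1500 nM.
compound 3, `O=C(C1CCC(C(F)(F)F)CC1)N1CC(c2nc(-c3cccc(Cl)c3)no2)C1`, gives 1000 nM.
compound 2, `Cc1cccc(-c2noc(C3CN(S(=O)(=O)c4ccc(F)cc4)C3)n2)c1`, gives only a limit of the assay, > 10000 nM.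

Among the two numbers, compound 1 holds the higher one, and the nearest measured step, a 1.5-fold lower number from compound 1 to compound 3 (0.18 log units; within the scatter), is small. Compound 2 shows only a limit (the limit of > 10000 nM in this assay, at which 1 of the 3 values shown sits), so its distance from compound 1 cannot be stated as a step.

Compound 4, `O=C(C1CCCO1)N1CC(c2nc(-c3cccc(Cl)c3)no2)C1`, differs from compound 1 in a single place: oxolan-2-yl in place of 4-methylcyclohexyl on a carbonyl carbon.

Going by the values given here, neither measured step covers this kind of change: the one from compound 1 to compound 3 changes only a substituent on the saturated ring, and the pair of compound 1 and compound 2 alters the linker rather than the ring. Among the compounds with values here, with no close precedent, the expectation for compound 4 is a modest move toward a higher number, with wide uncertainty: compound 4 is estimated at 4000 nM, between 1000 nM and 15000 nM, which would mean an estimated step of a 2.7-fold higher number from compound 1 to compound 4 (0.43 log units; beyond the scatter).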

Compound 4, half-maximal effective concentration: > 10000 nM
Compound 4 was reported as a limit; the forecaster's own chance of this, stated with the estimate: 35%; at least 2.5-fold (0.39 log units) between middle value and limit.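

In this assay, the group on this carbonyl carbon turns out to matter: the earlier step, a 1.5-fold lower number from compound 1 to compound 3 (0.18 log units; within the scatter), changed only a substituent on the saturated ring, whereas replacing the whole ring gives an at least 6.6-fold higher number from compound 1 to compound 4 (0.82 log units; beyond the scatter). The size of this step is only a lower bound, and the true gap may be larger. Compound 4 is reported only as a limit of the assay, the same limit that compound 2 reaches: the limit of > 10000 nM in this assay, at which 2 of the 4 values shown sit.

The change from 4-methylcyclohexyl to oxolan-2-yl alters ring size, brings in a ring oxygen and removes the methyl all at once, and the compounds shown cannot separate these three differences. A cyclopentyl group, which has the smaller ring without the oxygen, or an oxan-4-yl group, which has the oxygen in a six-membered ring, would pull them apart.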